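Swapping a halogen on the benzimidazole of a bile acid receptor antagonist

A few compounds are considered here, and "the series" means these few. Any claim that something is new, unique, unknown or untested is made for them only; others in the source may bear on it.

Measured compounds:
- Compound 1 `CC(=O)N1CCC(C[C@@H](c2nc3ccc(C)cc3n2C)N2C(=O)CN(c3ccc(Oc4ccccc4)cc3)C2=O)CC1`: 0.2 nM
- Compound 2 `CC(=O)N1CCC(C[C@@H](c2nc3ccccc3n2C)N2C(=O)CN(c3ccc(Oc4ccccc4)cc3)C2=O)CC1`: 0.002 nM
- Compound 3 `CC(=O)N1CCC(C[C@@H](c2nc3cc(F)ccc3n2C)N2C(=O)CN(c3ccc(Oc4ccccc4)cc3)C2=O)CC1`: 1 nM

In an assay on cells for antagonist activity at Bile acid receptor (Homo sapiens), read by a luciferase reporter, with a stated time of 24 h (a lower number here means a stronger inhibitor, a higher number a weaker inhibitor), compound 3 gives the highest number of the three, the weakest inhibitor shown. Compound 4 `CC(=O)N1CCC(C[C@@H](c2nc3ccc(Cl)cc3n2C)N2C(=O)CN(c3ccc(Oc4ccccc4)cc3)C2=O)CC1` differs from it in one place: 6-chloro-1-methyl-1H-benzimidazol-2-yl in place of 5-fluoro-1-methyl-1H-benzimidazol-2-yl on a saturated chain carbon bound to an amide-type nitrogen in a ring and a saturated chain carbon. Within the data shown here, two steps bear on this. Adding a fluoro gave a 500-fold higher number from compound 2 to compound 3 (2.70 log units; beyond the scatter), while removing a methyl gave a 100-fold lower number from compound 1 to compound 2 (2.00 log units; beyond the scatter); between the two substituted rings the step was a 5.0-fold higher number from compound 1 to compound 3 (0.70 log units; beyond the scatter). A substituent on that ring has thus so far raised the number, but the 6-methyl compound 1 sits lower than compound 3. With a chloro in the same place as that methyl, compound 4 is expected to resemble compound 1, giving an estimated step of a 3.3-fold lower number from compound 3 to compound 4 (0.52 log units; beyond the scatter). The expected value for compound 4 is 0.3 nM, within 0.03 nM to 3 nM.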

Compound 4, half-maximal inhibitory concentration: 0.8 nM
Compound 4: the middle estimate sits 2.7-fold (0.43 log units) below what was measured, within the range that was stated.
By their numbers in this assay, from the lowest: compound 2; then compound 1; then compounds 4 and 3 (each within the scatter of the next).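

Exchanging 5-fluoro-1-methyl-1H-benzimidazol-2-yl for 6-chloro-1-methyl-1H-benzimidazol-2-yl leaves the number essentially unchanged (a 1.3-fold lower number from compound 3 to compound 4 (0.10 log units; within the scatter)). Chloro does not reproduce methyl on that aromatic carbon (a 4.0-fold higher number from compound 1 to compound 4 (0.60 log units; beyond the scatter)), and compound 2, with hydrogen there, remains far lower (a 400-fold higher number from compound 2 to compound 4 (2.60 log units; beyond the scatter)). No measurement here explains these differences.

Going by these compounds, the halogen and its place on the ring change together between compound 3 and compound 4, so their separate contributions remain unknown. On these data alone, it also remains open whether a methoxy or a nitrile on this ring would come closer to compound 2.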